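This account rests on a few compounds, and the source may have more. Where it says the series, first, only, none or still open, it means among the compounds named here.

Compounds measured so far: compound 1 `CCN(CC)S(=O)(=O)c1ccc(S(=O)(=O)N2CCC[C@@H](C(=O)N[C@H]3CC[C@H](OC)CC3)C2)cc1` and compound 2 `CCN(CC)S(=O)(=O)c1ccc(S(=O)(=O)N2CCC[C@@H](C(=O)N3CCC(COC)CC3)C2)cc1`.

In a functional assay on MIA PaCa-2 cells (Homo sapiens) for inhibition, read by MTT assay, with a stated time of 3 days (a lower number here means a stronger inhibitor, a higher number a weaker inhibitor), compound 1 gives 2290 nM. Among the compounds with values here, compound 2 has the lowest number of the two: in this assay compound 2 gives 50 nM, and the only other compound lies well away from it, a 46-fold lower number from compound 1 to compound 2 (1.66 log units; beyond the scatter).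

Compound 3 `CCN(CC)S(=O)(=O)c1ccc(S(=O)(=O)N2CCC[C@@H](C(=O)N[C@@H]3CCOC3)C2)cc1` is not yet measured. It differs from compound 2 in one place: (oxolan-3-yl)amino in place of 4-(methoxymethyl)piperidin-1-yl on a carbonyl carbon. Within the data shown here, the one step that bears on this change runs the other way, a 46-fold lower number from compound 1 to compound 2 (1.66 log units; beyond the scatter), where an amino substituent on the carbonyl carbon, (4-methoxycyclohexyl)amino, was replaced by 4-(methoxymethyl)piperidin-1-yl. Compound 3 brings back an amino substituent on that carbonyl carbon, now (oxolan-3-yl)amino, a smaller five-membered ring. On this evidence a step back toward the number of compound 1 is expected, though the ring is not the same and the size of the step is uncertain. Compound 3 is therefore estimated at 1500 nM, with a range from 300 nM to 8000 nM, which would mean an expected step of a 30-fold higher number from compound 2 to compound 3 (1.48 log units; beyond the scatter).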

Compound 3, half-maximal inhibitory concentration: 100 nM
The estimate for compound 3 lay 15-fold (1.18 log units) above the measured number, and the stated range ends above it.
By their numbers in this assay, from the lowest: compounds 2 and 3 (each within the scatter of the next); then compound 1.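

In this assay the amide hydrogen does not by itself go with a high number: the step of a 2.0-fold higher number from compound 2 to compound 3 (0.30 log units; within the scatter) leaves (oxolan-3-yl)amino and 4-(methoxymethyl)piperidin-1-yl on this carbonyl carbon indistinguishable. The amide-type nitrogen stays in place in the step of a 23-fold lower number from compound 1 to compound 3 (1.36 log units; beyond the scatter), so a large change also follows when only oxolan-3-yl replaces 4-methoxycyclohexyl on that nitrogen. Among these three compounds, the high number of compound 1 therefore goes with the 4-methoxycyclohexyl group and not simply with the presence of an amino substituent on the carbonyl carbon, and neither compound 2 nor compound 3 goes against this reading. Nothing available here bears on the reason for these results.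

From the compounds shown here alone, it remains open whether a plain cyclohexyl group without its methoxy group, or an open 2-methoxyethyl chain, on the amide-type nitrogen would give a number near that of compound 3 or near that of compound 1. Going by these compounds, the effect of the opposite configuration at the stereocentre of the oxolan-3-yl group also remains open.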